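The source may hold more compounds than are shown below. What is called first, only, known or untested is meant among the compounds shown, and "the series" means these compounds.

In an ADME assay on MRC5 cells (Homo sapiens) for cytotoxicity, read by MTT assay, with a stated time of 72 h (a lower number here means a stronger inhibitor, a higher number a weaker inhibitor), compound 1 `O=C(Nc1nnc(-c2cccc(O)c2O)s1)c1ccc(Cl)cc1` gives 18700 nM, compound 2 `O=C(COc1ccccc1)Nc1nnc(-c2cccc(O)c2O)s1` gives 33900 nM and compound 3 `O=C(Nc1nnc(-c2cccc(O)c2O)s1)c1ccccc1` gives 23200 nM. Compound 3 stands within the scatter of both others. Compound 4 `CC(=O)Nc1nnc(-c2cccc(O)c2O)s1` has methyl in place of phenyl on a carbonyl carbon. Two measured steps change the group at that carbonyl carbon: a 1.8-fold higher number from compound 1 to compound 2 (0.26 log units; within the scatter) and a 1.5-fold lower number from compound 2 to compound 3 (0.16 log units; within the scatter). Hydrogen in place of chloro on an aromatic carbon gives a 1.2-fold higher number from compound 1 to compound 3 (0.09 log units; within the scatter). All three lie within the scatter, though none replaces the ring with so small a group. No step beyond the scatter is therefore expected in this assay, and the expected step is a 1.2-fold higher number from compound 3 to compound 4 (0.08 log units; within the scatter). For compound 4 the estimated value is 28000 nM, with an expected range of 12000 nM to 60000 nM.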

Compound 4, half-maximal inhibitory concentration: 156000 nM
Compound 4: middle estimate off by 5.6-fold (0.75 log units), on the low side, outside the stated range (above it).
By their numbers in this assay, from the lowest: compounds 1, 3 and 2 (each within the scatter of the next); then compound 4.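

At the carbonyl carbon in this assay, replacing the ring-bearing group with methyl now moves the number beyond the scatter: a 6.7-fold higher number from compound 3 to compound 4 (0.83 log units; beyond the scatter) for phenyl, an 8.3-fold higher number from compound 1 to compound 4 (0.92 log units; beyond the scatter) for 4-chlorophenyl and a 4.6-fold higher number from compound 2 to compound 4 (0.66 log units; beyond the scatter) when hydrogen replaces phenoxy on the chain. Compounds 1, 2 and 3 all carry an aromatic ring in this group and stand within the scatter of one another, while compound 4 alone has none. No measured evidence accounts for this step.

From the compounds shown here alone, whether the ring itself or only the size of the group matters stays open. Cyclohexyl or a longer chain such as n-butyl on that carbonyl carbon would separate the two.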